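A few compounds are considered here, and "the series" means these few. Any claim that something is new, unique, unknown or untested is made for them only; others in the source may bear on it.

In an ADME assay on HEK293 cells (Homo sapiens) for cytotoxicity, with a stated time of 72 h (a lower number here means that less compound is needed, a higher number that more compound is needed for the effect), compound 1 `C=C[C@@](C)(/C=C/c1ccc(OCc2ccccc2)cc1)CCC=C(C)C` reads > 36600 nM as a limit and not a number. Compound 2 `C=C[C@@](C)(/C=C/c1ccc(O)c(/C=C/C(=O)c2ccccc2)c1)CCC=C(C)C` reads > 7410 nM as a limit as well. Compound 3 `C=C[C@@](C)(/C=C/c1ccc(Nc2ccccc2)cc1)CCC=C(C)C` reads > 36600 nM as a limit too, so no number is in hand for where compound 3 stands. Of the values in this small set, the limit of > 36600 nM in this assay, at which 2 of the 3 values shown sit, and the limit of > 7410 nM in this assay, at which 1 of the 3 values shown sits, in the same way.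

Among the measured compounds shown here, the step to compound 4 `C=C[C@@](C)(/C=C/c1ccc(Nc2ccc(OC)c(F)c2)cc1)CCC=C(C)C` is 3-fluoro-4-methoxyphenyl in place of phenyl on a nitrogen on an aromatic ring and no measured pair tests such a replacement on that nitrogen. For the measured compounds named here, the only measured step that bears on it is a step that the two limits leave unreadable from compound 1 to compound 3 and it gives no size to carry over.

In this assay the expected change is none beyond the scatter and in no set direction, with an at least 1.2-fold lower number from compound 3 to compound 4 (0.08 log units; that floor lies within the scatter) as the estimated step. That expectation rests on compound 3 and its limit > 36600 nM alone. The estimate for compound 4 is 30000 nM with an expected range from 9000 nM to 60000 nM and a limit is the likely report.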

Compound 4, half-maximal effective concentration: > 36600 nM
Compound 4: no number, only a limit; the forecaster's own chance of this, stated with the estimate: 80%; middle value at least 1.2-fold (0.08 log units) away from the limit.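

In this assay compound 4 gives > 36600 nM, a limit and not a number. Among the compounds shown here, with compound 3 also standing as a limit, no step between compound 3 and compound 4 can be read. The compounds shown leave open what size, if any, the change from phenyl to 3-fluoro-4-methoxyphenyl has.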